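From Thiophene Amide to Thiophene Sulfonamide on One Core

The source may report more compounds than this note shows. Statements on the series, on what has been measured and on what is new or still open speak of the compounds shown alone.

Measured compounds in a functional assay on SW-620 cells (Homo sapiens) for cytotoxicity, read by MTT assay, with a stated time of 48 h; on this read-out higher numbers stand for weaker inhibition and lower numbers for stronger inhibition:
- compound 1, `CCCCCCCCCCCCNC(=O)[C@@H](NC(=O)c1cccs1)[C@@H](C)O`: compound 1 gives 29200 nM
- compound 2, `CCCCCCCCCCCCNC(=O)[C@@H](NC(=O)c1cc2ccccc2o1)[C@@H](C)O`: compound 2 gives 21300 nM
- compound 3, `CCCCCCCCCCCCNC(=O)[C@@H](NC(=O)c1cc2ccccc2n1C)[C@@H](C)O`: compound 3 gives only a limit, > 200000 nM

Compound 1 stands at the higher of the two numbers that were actually measured, but its nearest neighbour, compound 2, is separated from it only by a 1.4-fold lower number from compound 1 to compound 2 (0.14 log units; within the scatter), so the two cannot be ordered. For compound 3 the assay reports a limit (the limit of > 200000 nM in this assay, at which 1 of the 3 values shown sits); against it, the step of an at least 6.8-fold higher number from compound 1 to compound 3 (0.83 log units; beyond the scatter) and the step of an at least 9.3-fold higher number from compound 2 to compound 3 (0.97 log units; beyond the scatter) are the only ones that lie beyond the scatter, and both concern the aromatic group on the carbonyl carbon.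

Compound 4, `CCCCCCCCCCCCNC(=O)[C@@H](NS(=O)(=O)c1cccs1)[C@@H](C)O`, differs from compound 1 elsewhere: (thiophen-2-yl)sulfonyl in place of (thiophen-2-yl)carbonyl on an amine nitrogen. Among the measured compounds shown here, none of the measured steps alters this linkage; all three keep the carbonyl and vary the aryl group, so they give no direct guide to the amide-to-sulfonamide exchange. For the measured compounds named here, with no bearing step, the expected outcome in this assay is a step of a 1.2-fold higher number from compound 1 to compound 4 (0.08 log units; within the scatter), that is, none beyond the scatter, with a broad band of uncertainty. Compound 4 is therefore estimated at 35000 nM, between 10000 nM and 150000 nM.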

Compound 4, half-maximal inhibitory concentration: 27900 nM
For compound 4 the middle estimate is 1.3-fold (0.10 log units) above the measured one, within the range that was stated.
By their numbers in this assay, from the lowest: compounds 2, 4 and 1 (each within the scatter of the next). At a limit, above all of these: compound 3.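

In this assay, the exchange of (thiophen-2-yl)carbonyl for (thiophen-2-yl)sulfonyl on an amine nitrogen gives a 1.0-fold lower number from compound 1 to compound 4 (0.02 log units; within the scatter), so with the thiophen-2-yl group held fixed, the linkage itself could be altered with no change beyond the scatter. Among the compounds shown here, the earlier steps had kept the carbonyl and varied only the aromatic group, so this is the first sign that the read-out at this position tolerates an exchange of the linking group as well, at least for this one aromatic group. Nothing measured here explains why the two linkages give values within the scatter of each other.

For the compounds shown here, it remains open whether the same exchange would hold with 1-benzofuran-2-yl or 1-methyl-1H-indol-2-yl in place of thiophen-2-yl, since the sulfonyl linkage appears here with only one aromatic group. Also open, going by these compounds, is how a urea or a plain methylene linkage on that amine nitrogen would read, and whether the sulfonyl result would persist with a shorter chain on the amide.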